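Para Dimethylamino Replacing Fluoro on the Benzylidene Ring

The source may report more compounds than this note shows. Statements on the series, on what has been measured and on what is new or still open speak of the compounds shown alone.

Measured compounds in a functional assay on MIA PaCa-2 cells (Homo sapiens) for cytotoxicity, read by MTT assay, with a stated time of 72 h; on this read-out higher numbers stand for an effect only at larger amounts of compound and lower numbers for an effect already at smaller amounts:
compound 1 `O=C1/C(=C\c2c(Cl)cccc2Cl)c2ccccc2N1c1c(Cl)cccc1Cl` — only a limit, > 100 ug/mL
compound 2 `O=C1/C(=C\c2ccc(F)cc2)c2ccccc2N1c1c(Cl)cccc1Cl` — 5 ug/mL

Two compounds share the same core and differ only in the aryl group on the exocyclic double bond. Compound 1 reaches no number in this assay, only a limit, > 100 ug/mL. Going by the values given here, compound 2 gives 5 ug/mL, the only real number in the set, so compound 2 stands as the single fixed point against which anything new is judged. The step of an at least 20-fold lower number from compound 1 to compound 2 (1.30 log units; beyond the scatter) is large, and its true size is open because compound 1 sits at the limit of > 100 ug/mL in this assay, at which 1 of the 2 values shown sits.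

Compound 3 `CN(C)c1ccc(/C=C2\C(=O)N(c3c(Cl)cccc3Cl)c3ccccc32)cc1` carries the change (dimethylamino in place of fluoro on an aromatic carbon). Among the compounds with values here, no measured step alters this position in the same way: the one known step swaps the whole aryl pattern, not a single para substituent, so it says little about the direction here. Without a guide, compound 3 is expected near compound 2, with the step of no change at the digits printed from compound 2 to compound 3 (within the scatter) estimated as none beyond the scatter. The estimate for compound 3 in this assay is 5 ug/mL, in the range 1.5 ug/mL to 20 ug/mL.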

Compound 3, concentration for half-maximal effect: > 100 ug/mL
Compound 3 ended at the assay's limit; the forecaster's own chance of this, stated with the estimate: 10%; middle value at least 20-fold (1.30 log units) away from the limit.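

In this assay, dimethylamino in place of fluoro on this one aromatic carbon gives an at least 20-fold higher number from compound 2 to compound 3 (1.30 log units; beyond the scatter), so the earlier finding is sharpened: replacing the whole aryl pattern is not needed, and a change to a single substituent para to a large group is enough to leave no measurable number. Going by these compounds alone, the reading for compound 3 is a limit and not a number, so the true size of this step stays open, and most of the set now rests at that same ceiling: the limit of > 100 ug/mL in this assay, at which 2 of the 3 values shown sit. The step between compound 1 and compound 3 cannot be read, as both values are limits, which leaves compound 2 as the only compound with a real number.

One pair cannot show whether fluoro is special at this position or dimethylamino is uniquely unfavourable there. A methoxy group, a plain amino group or a carboxylic acid on the same carbon would help separate these two readings, and the compounds shown say nothing about whether any of them would keep a number in this assay.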